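A few compounds are considered here, and "the series" means these few. Any claim that something is new, unique, unknown or untested is made for them only; others in the source may bear on it.

Series notes. Among the measured compounds shown here, compound 1 `COc1ccc(S(=O)(=O)c2cc3cnc(Nc4ccc5[nH]ccc5c4)nc3n(C)c2=O)cc1` carries a (4-methoxyphenyl)sulfonyl group on the shared core; in a functional assay on K562 cells (Homo sapiens) for inhibition, read by trypan blue exclusion, with a stated time of 72 h (a higher number here means a weaker inhibitor, a lower number a stronger inhibitor), compound 1 gives 300 nM, the lowest of the three numbers so far. Compound 2 `COc1ccc(S(=O)(=O)c2cc3cnc(Nc4cccc5[nH]ccc45)nc3n(C)c2=O)cc1` differs only at the amine, 1H-indol-4-yl in place of 1H-indol-5-yl on a nitrogen on an aromatic ring, and in this assay compound 2 gives 5000 nM; the step is a 17-fold higher number from compound 1 to compound 2 (1.22 log units; beyond the scatter). Compound 3 `Cn1c(=O)c(S(=O)(=O)c2ccc(F)cc2F)cc2cnc(Nc3ccccn3)nc21` differs from compound 1 in more than one place, and in this assay compound 3 gives 35000 nM.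

Compound 4 `Cc1ccc(S(=O)(=O)c2cc3cnc(Nc4ccc5[nH]ccc5c4)nc3n(C)c2=O)cc1` is not yet measured. Relative to compound 1 the change is methyl in place of methoxy on an aromatic carbon. For the measured compounds named here, no measured step touches the sulfonyl aryl group: the only step available, a 17-fold higher number from compound 1 to compound 2 (1.22 log units; beyond the scatter), concerns the amine, and compound 3 changes several places at once, so nothing measured shows how this assay responds to this exchange. Without precedent, the expectation for compound 4 is a step within the scatter, a 1.3-fold higher number from compound 1 to compound 4 (0.12 log units; within the scatter), with a range widened for the lack of evidence. Compound 4 is expected to give 400 nM in this assay, between 130 nM and 1300 nM.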

Compound 4, half-maximal inhibitory concentration: 750 nM
Beside the measured number, compound 4's estimate is 1.9-fold (0.27 log units) below it; low and high end bracket the measured number.
By their numbers in this assay, from the lowest: compound 1; then compound 4; then compound 2; then compound 3.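

The sulfonyl aryl group now has a single-place step of its own in this assay: with methyl in place of methoxy on the aromatic carbon para to a large group, the step (a 2.5-fold higher number from compound 1 to compound 4 (0.40 log units; beyond the scatter)) is modest but beyond the scatter. This exchange moves the number less than the change at the amine (a 17-fold higher number from compound 1 to compound 2 (1.22 log units; beyond the scatter)) does, so of the two places tested from compound 1, the amine gives the larger step. Nothing among the data shown accounts for the step from methoxy to methyl.

On these data alone, whether ethoxy, a chlorine atom or a hydrogen at this place would read closer to compound 1 or to compound 4 stays open. Also open, as far as these compounds go, is whether the same exchange gives a similar step with the 1H-indol-4-yl amine of compound 2.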